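Working notes: compound 4 against compound 1

The compounds below may be only part of what the source reports. "The series", "measured", "known", "first", "only" and "open" are said of these compounds alone.

Among the compounds with values here, compound 1 `CN1CCN(C(=O)/C=C/c2ccncc2-c2ccc3ccccc3c2)CC1` gives the highest of the three numbers so far in an assay on a protein complex for inhibition of CDK8/Cyclin C (Homo sapiens), with a stated time of 1 h, tested at 10 uM (on this read-out higher numbers stand for more inhibition at the one concentration tested (going by the name of the read-out) and lower numbers for less inhibition), at 101%. Compound 2 `CNC(=O)/C=C/c1ccncc1-c1ccc2cccnc2c1` stands nearest, with 82% in this assay, a gap beyond the scatter. Compound 3 `O=C(COc1ccncc1-c1ccc2ccccc2c1)N1CCOCC1` is furthest away, at 9% in this assay, again beyond the scatter.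

Compound 4 `CCOC(=O)/C=C/c1ccncc1-c1ccc2ccccc2c1` is not yet measured. It differs from compound 1 in one place: ethoxy in place of 4-methylpiperazin-1-yl on a carbonyl carbon, that is, (4-methylpiperazin-1-yl)carbonyl to ethoxycarbonyl. Within the data shown here, no step between measured compounds covers this change. Going by these compounds, compound 2 shows that the group on the carbonyl carbon can be altered while a high number remains, but ethoxy is untested. A downward step beyond the scatter is expected for compound 4 in this assay, a number 41 percentage points lower from compound 1 to compound 4 (beyond the scatter). Compound 4 is estimated at 60%, within a range of 20% to 95%.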

Compound 4, a percentage reported as inhibition, at one concentration (the size of the read-out at that concentration, not a potency): 102%
Estimate against measurement, compound 4: 42 percentage points below; the whole stated range lies below it.
By their numbers in this assay, from the lowest: compound 3; then compound 2; then compounds 1 and 4 (each within the scatter of the next).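

In this assay, ethoxy in place of 4-methylpiperazin-1-yl on a carbonyl carbon gives a number 1 percentage points higher from compound 1 to compound 4 (within the scatter). At this position, then, a high number does not depend on the 4-methylpiperazin-1-yl ring, and the ethoxycarbonyl compound stands level with the amide compound 1. Nothing on hand accounts for this result.

Open, going by these compounds, is whether a carboxylic acid or a longer chain such as butoxy on the same carbonyl carbon would also give a high number. A reading at one concentration also leaves open whether compound 1 and compound 4 would separate in potency.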